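A few compounds are considered here, and "the series" means these few. Any claim that something is new, unique, unknown or untested is made for them only; others in the source may bear on it.

Compound 1 `CCCOC(=O)Nc1ccc([Se]C#N)cc1`: 21100 nM
Compound 2 `N#C[Se]c1ccc(NC(=O)Oc2ccc(Cl)cc2)cc1`: 6400 nM
Compound 3 `O=C(Nc1ccc([Se][Se]c2ccc(NC(=O)Oc3ccc(F)cc3)cc2)cc1)Oc1ccc(F)cc1`: 4900 nM

All three were measured in a functional assay on PC-3 cells (Homo sapiens) for cytotoxicity, read by MTT assay, with a stated time of 72 h; a higher number here means a weaker inhibitor of growth, a lower number a stronger inhibitor of growth. Compound 1 gives the highest number of the three; compound 2 lies nearest to it and compound 3 furthest, and both sit lower by more than the usual scatter. Compound 4 `CCCCOC(=O)Nc1ccc([Se]C#N)cc1` has not been measured yet. It differs from compound 1 in a single place: methyl in place of hydrogen on a saturated chain carbon, three bonds along the chain from an oxygen next to a carbonyl group. Among the compounds with values here, no pair of measured compounds shows this change on its own, so there is no measured step to lean on. A change this small is expected to move the number only a little, if at all, with any shift more likely toward a lower value than a higher one. Compound 4 is therefore estimated at 16000 nM, with a range from 6000 nM to 42000 nM. This estimate corresponds to an expected step of a 1.3-fold lower number from compound 1 to compound 4 (0.12 log units; within the scatter).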

Compound 4, concentration for 50% growth inhibition: 12400 nM
Compound 4: the middle estimate sits 1.3-fold (0.11 log units) above what was measured; the measured number falls inside the stated range.
By their numbers in this assay, from the lowest: compounds 3, 2, 4 and 1 (each within the scatter of the next, the first and the last beyond it).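

In this assay, going from propyl to butyl, with methyl in place of hydrogen three bonds along the chain from an oxygen next to a carbonyl group, gives a 1.7-fold lower number from compound 1 to compound 4 (0.23 log units; within the scatter). Within the data shown here, this is the first measured step at this position, and it shows that this one added carbon does not move the number beyond the usual scatter. No measurement shown here explains the result. Still open, on these data alone, is whether a longer chain, such as hexyl, or an amine on the chain would give a step beyond the scatter.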